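A few compounds are considered here, and "the series" means these few. Any claim that something is new, unique, unknown or untested is made for them only; others in the source may bear on it.

Measured in a functional assay on A549 cells (Homo sapiens) for antiproliferative activity, read by spectrophotometry, with a stated time of 2 days; on this read-out lower numbers stand for stronger inhibition of growth and higher numbers for weaker inhibition of growth:

- Compound 1 `COc1ccc(Nc2ncc(C(F)(F)F)c(N3Cc4cccc(N(C)S(C)(=O)=O)c4C3)n2)cc1C(F)(F)F`: > 30000 nM
- Compound 2 `Cc1cc(F)ccc1Nc1ncc(C(F)(F)F)c(N2Cc3cccc(N(C)S(C)(=O)=O)c3C2)n1`: > 30000 nM
- Compound 3 `CN(c1cccc2c1CN(c1nc(Nc3cccc(Oc4ccccc4)c3)ncc1C(F)(F)F)C2)S(C)(=O)=O`: 19000 nM

The first two entries are limits of the assay and not numbers. Within the data shown here, compound 3 gives the only true number, 19000 nM. Compound 2 sits at the limit of > 30000 nM in this assay, at which 2 of the 3 values shown sit. That is all that can be said of its standing, as no exact value exists for it.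

Compound 4 `Cc1ccc(Nc2ncc(C(F)(F)F)c(N3Cc4cccc(N(C)S(C)(=O)=O)c4C3)n2)c(C)c1` keeps the shared core of compound 2 and changes one substituent, turning 4-fluoro-2-methylphenyl into 2,4-dimethylphenyl: methyl in place of fluoro on an aromatic carbon. In words, this is methyl in place of fluoro on an aromatic carbon, para to a large group.

Among the measured compounds shown here, the one measured step that bears on this is a step that the two limits leave unreadable from compound 1 to compound 2. There, a larger change of the same aromatic group gave no readable number at either end, so it offers no size to carry over. With so little to go on, no shift beyond the usual scatter is expected in this assay, in either direction. The expected step that the limit leaves unreadable from compound 2 to compound 4 is therefore no real change, and another limit is the likeliest report. For compound 4 the estimate is 35000 nM, with an expected range from 18000 nM to 60000 nM.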

Compound 4, concentration for 50% growth inhibition: 20700 nM
Compound 4: the middle estimate sits 1.7-fold (0.23 log units) above what was measured, and the stated range covers the measured number.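

In this assay, methyl in place of fluoro on this aromatic carbon, para to a large group, yields a true number, whereas the earlier change between compound 1 and compound 2 cannot be read, as both of its ends are limits. This small swap gives an at least 1.4-fold lower number from compound 2 to compound 4 (0.16 log units; that floor lies within the scatter), and the larger change of the whole aromatic group gives an at least 1.4-fold lower number from compound 1 to compound 4 (0.16 log units; that floor lies within the scatter), so each step has a floor but no exact size, and neither floor by itself establishes a real gain. Compound 2 remains a limit of the assay and not a number: the limit of > 30000 nM in this assay, at which 2 of the 4 values shown sit.

As far as these compounds go, the real size of the methyl-for-fluoro step stays open, as it could be close to its floor or considerably larger. From the compounds shown here alone, it is also open whether a chloro group, a nitrile or an amine on this same aromatic carbon would give a readable number, and how such a number would compare with that of compound 4.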